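Aryl swaps at the para position: carboxyphenyl step

A few compounds are considered here, and "the series" means these few. Any claim that something is new, unique, unknown or untested is made for them only; others in the source may bear on it.

Compound 3 `CCC(C)(C)Cc1c[nH]c(CCc2ccc(-c3ccc(F)cn3)cc2)n1` gives 97 nM in a functional assay on HEK293 cells for agonist activity at Bombesin receptor subtype-3 (Homo sapiens), read by luminescence and calcium flux, with a stated time of 10 min (a lower number here means that less compound is needed, a higher number that more compound is needed for the effect), and stands second highest of the three numbers, all within the scatter of each other. Compound 1 `CCC(C)(C)Cc1c[nH]c(CCc2ccc(-c3cnsc3)cc2)n1` gives 100 nM and compound 2 `CCC(C)(C)Cc1c[nH]c(CCc2ccc(-c3cccc(C#N)n3)cc2)n1` gives 95 nM. The steps of a 1.1-fold lower number from compound 1 to compound 2 (0.02 log units; within the scatter), a 1.0-fold lower number from compound 1 to compound 3 (0.01 log units; within the scatter) and a 1.0-fold higher number from compound 2 to compound 3 (0.01 log units; within the scatter) show that swapping one heteroaryl for another at this carbon left the number unchanged. Compound 4 `CCC(C)(C)Cc1c[nH]c(CCc2ccc(-c3ccccc3C(=O)O)cc2)n1` is not yet measured; it carries 2-carboxyphenyl in place of 5-fluoropyridin-2-yl on an aromatic carbon. Among the compounds with values here, no measured step covers a carboxylic acid, so the unchanged heteroaryl swaps are only weak guides. Compound 4 is expected to give 300 nM, within 70 nM to 1500 nM, which means an estimated step of a 3.1-fold higher number from compound 3 to compound 4 (0.49 log units; beyond the scatter).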

Compound 4, half-maximal effective concentration: 101 nM
Beside the measured number, compound 4's estimate is 3.0-fold (0.47 log units) above it; the range from low to high includes it.
By their numbers in this assay, from the lowest: compounds 2, 3, 1 and 4 (each within the scatter of the next).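

In this assay the move to 2-carboxyphenyl gives a 1.0-fold higher number from compound 3 to compound 4 (0.02 log units; within the scatter), alongside a 1.1-fold higher number from compound 2 to compound 4 (0.03 log units; within the scatter) and a 1.0-fold higher number from compound 1 to compound 4 (0.00 log units; within the scatter). The flat response at this aromatic carbon therefore extends beyond the heteroaryl groups to a ring of carbon only that carries a carboxylic acid and a hydrogen-bond donor. No supporting data bear on why the number stays level.

Going by these compounds, whether an amine or a primary amide in place of the carboxylic acid would leave the number level stays open. So does the outcome with a saturated ring such as cyclohexyl in place of the aromatic ring.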